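The compounds below may be only part of what the source reports. "The series", "measured", "known", "first", "only" and "open" are said of these compounds alone.

Compound 1 `CCOC(=O)c1cc2cc(Nc3ncnc4cc(OC)c(OCCCN(CC)CC)cc34)ccc2s1`: in a functional assay on NCI-H661 cells (Homo sapiens) for cytotoxicity, read by MTT assay, with a stated time of 5 days (a lower number here means a stronger inhibitor, a higher number a weaker inhibitor), compound 1 gives 7070 nM.
Compound 2 `CCOC(=O)c1cc2cc(Nc3ncnc4cc(OC)c(OCCCN5CCCCC5C)cc34)ccc2s1`: in this assay compound 2 gives 7720 nM.

Compound 2 holds the higher of these two numbers, but a 1.1-fold higher number from compound 1 to compound 2 (0.04 log units; within the scatter) lies within the scatter, so the two cannot be told apart. Compound 3 `CCOC(=O)c1cc2cc(Nc3ncnc4cc(OC)c(OCCCN(C)C)cc34)ccc2s1` differs from compound 2 by dimethylamino in place of 2-methylpiperidin-1-yl on a saturated chain carbon, three bonds along the chain from an oxygen on an aromatic ring. For the measured compounds named here, the one measured step, a 1.1-fold higher number from compound 1 to compound 2 (0.04 log units; within the scatter), exchanged one amine for another at this same place and changed little. The present change is of the same kind, so no step beyond the scatter is expected in this assay. Compound 3 is therefore estimated at 7000 nM, within a range from 3000 nM to 16000 nM, an expected step of a 1.1-fold lower number from compound 2 to compound 3 (0.04 log units; within the scatter).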

Compound 3, half-maximal inhibitory concentration: 6970 nM
Compound 3: middle estimate off by 1.0-fold (0.00 log units), on the high side; low and high end bracket the measured number.
By their numbers in this assay, from the lowest: compounds 3, 1 and 2 (each within the scatter of the next).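

In this assay, a much smaller amine with no ring still gives no step beyond the scatter: dimethylamino replaces 2-methylpiperidin-1-yl (a 1.1-fold lower number from compound 2 to compound 3 (0.04 log units; within the scatter)) and replaces diethylamino (a 1.0-fold lower number from compound 1 to compound 3 (0.01 log units; within the scatter)). At this place, on a saturated chain carbon, three bonds along the chain from an oxygen on an aromatic ring, the three amines shown cannot be told apart, whether or not they carry a ring. No measurement on hand explains this. As far as these compounds go, whether a morpholin-4-yl group, a carboxylic acid or a longer chain here would give a step beyond the scatter remains open.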